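Chloro to Trifluoromethyl: Estimating Compound 4

The source may report more compounds than this note shows. Statements on the series, on what has been measured and on what is new or still open speak of the compounds shown alone.

Compound 1 `O=C(/C=C\Nc1ccc(Cl)cc1)c1cn(-c2ccccc2)nc1-c1ccccc1`: 3610 nM
Compound 2 `O=C(/C=C\Nc1ccc(C(F)(F)F)cc1)c1cn(-c2ccccc2)nc1-c1ccccc1`: > 50000 nM (a limit of the assay)
Compound 3 `O=C(/C=C\Nc1ccc(Cl)cc1)c1cn(-c2ccccc2)nc1-c1ccc(F)cc1`: 4600 nM

In a functional assay on HT-29 cells (Homo sapiens) for antiproliferative activity, read by MTT assay, with a stated time of 48 h (on this read-out lower numbers stand for stronger inhibition and higher numbers for weaker inhibition), compound 1 gives 3610 nM. Compound 2 reaches only a limit of the assay, > 50000 nM. Compound 3 gives 4600 nM, and the step of a 1.3-fold higher number from compound 1 to compound 3 (0.11 log units; within the scatter) shows that fluoro in place of hydrogen on an aromatic carbon changes little. The change trifluoromethyl in place of chloro on an aromatic carbon gives the step of an at least 13-fold higher number from compound 1 to compound 2 (1.14 log units; beyond the scatter), a large one, ending at the limit of > 50000 nM in this assay, at which 1 of the 3 values shown sits. Compound 4 `O=C(/C=C\Nc1ccc(C(F)(F)F)cc1)c1cn(-c2ccccc2)nc1-c1ccc(F)cc1` carries the same kind of change, (trifluoromethyl in place of chloro on an aromatic carbon); the place lines match, but on the core of compound 3 the shared core bears the fluoro already described. Because compound 1 to compound 2 gave an at least 13-fold higher number from compound 1 to compound 2 (1.14 log units; beyond the scatter), a step of similar size is expected from compound 3, namely a 13-fold higher number from compound 3 to compound 4 (1.12 log units; beyond the scatter). Compound 4 is therefore estimated at 60000 nM, most likely again reported only as a limit.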

Compound 4, half-maximal inhibitory concentration: > 50000 nM
Compound 4: no number, only a limit; the forecaster's own chance of this, stated with the estimate: 70%; the middle value lies beyond the limit too.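

In this assay, trifluoromethyl in place of chloro again brings a large step on the core bearing the fluoro, with an at least 10-fold higher number from compound 3 to compound 4 (1.03 log units; beyond the scatter). The change thus carries over to a second core in the same direction, and the two steps can be set side by side: the same change on two cores in this assay, an at least 13-fold higher number (1.14 log units; beyond the scatter) from compound 1 to compound 2 and an at least 10-fold higher number (1.03 log units; beyond the scatter) from compound 3 to compound 4; the limit leaves it open whether they differ. Neither the true size of these steps nor the effect of the fluoro between compound 2 and compound 4 can be read, as both compounds sit at a limit of the assay: the limit of > 50000 nM in this assay, at which 2 of the 4 values shown sit.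

The compounds shown leave open whether a methyl, a methoxy or a bromo in this place would give a number rather than a limit on either core. They also leave open how an amine there would compare with chloro.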